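One Fluorine Atom on the Way from Compound 3 to Compound 4

The compounds below may be only part of what the source reports. "The series", "measured", "known", "first", "only" and "open" are said of these compounds alone.

The series rests on a shared core carrying an acetyl group and two aryl substituents. Compound 1 `CC(=O)c1cc(-c2ccccc2)cc2cc(-c3ccc(F)cc3)[nH]c12` carries a plain phenyl on one side and a 4-fluorophenyl on the other; in a functional assay on MCF7 cells (Homo sapiens) for cytotoxicity, read by MTT assay, with a stated time of 2 days, tested at 1 uM (a lower number here means a stronger effect, a higher number a weaker effect of the compound at the concentration tested), compound 1 gives 96.8%. Compound 2 `CC(=O)c1cc(-c2ccc(F)cc2)cc2cc(-c3ccc(F)cc3)[nH]c12` adds a second fluorine, and in this assay compound 2 gives 93.2%. Among the measured compounds shown here, the single step between them, a number 3.6 percentage points lower from compound 1 to compound 2 (within the scatter), is the only one of its kind among the measured compounds. Compound 3 `CC(=O)c1cc(/C=C/c2ccccc2)cc2cc(-c3ccccc3)[nH]c12` replaces one aryl group with a styryl arm; in this assay compound 3 gives 93.4%, the second highest of the three numbers, nearest to compound 2 and furthest from compound 1, both within the scatter.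

Compound 4 `CC(=O)c1cc(/C=C/c2ccccc2)cc2cc(-c3ccc(F)cc3)[nH]c12` is compound 3 with one change: fluoro in place of hydrogen on an aromatic carbon. For the measured compounds named here, the only step that bears on it is the one from compound 1 to compound 2, where the same change moved the read-out by an amount within the scatter. The author therefore expects no step beyond the scatter in this assay for compound 4, estimated at 91%, in the range 82% to 99%, which corresponds to an expected step of a number 2.4 percentage points lower from compound 3 to compound 4 (within the scatter).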

Compound 4, a percentage reported as activity, at one concentration (the size of the read-out at that concentration, not a potency): 86.9%
The estimate for compound 4 lay 4.1 percentage points above the measured number; low and high end bracket the measured number.
By their numbers in this assay, from the lowest: compounds 4, 2, 3 and 1 (each within the scatter of the next).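

With compound 4, the change from phenyl to 4-fluorophenyl can be read on a second core, and in this assay the two readings agree: the same change on two cores in this assay, a number 3.6 percentage points lower (within the scatter) from compound 1 to compound 2 and a number 6.5 percentage points lower (within the scatter) from compound 3 to compound 4, 2.9 percentage points apart, within the scatter of two such steps On the core with the 2-phenylethenyl arm, the fluoro on the aromatic carbon, para to a large group, gives a number 6.5 percentage points lower from compound 3 to compound 4 (within the scatter), so the result from the earlier pair is no longer confined to one core. Among the compounds shown here, compound 4 also allows the first reading of 2-phenylethenyl in place of an aryl group on the other side of the core, and this exchange stays within the scatter in both comparisons: against 4-fluorophenyl it gives a number 6.3 percentage points lower from compound 2 to compound 4 (within the scatter), and against phenyl it gives a number 9.9 percentage points lower from compound 1 to compound 4 (within the scatter).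

No step among these four compounds lies beyond the scatter, so it remains open whether either position can move this read-out at the one concentration tested. Whether an amine, a carboxylic acid or a longer chain at either position would give a step beyond the scatter is also left open by the compounds shown.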